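The compounds below may be only part of what the source reports. "The series", "measured", "known", "first", "only" and "open" are said of these compounds alone.

Working notes on the series. In a functional assay on MDA-MB-231 cells (Homo sapiens) for antiproliferative activity, read by MTT assay, with a stated time of 72 h (on this read-out lower numbers stand for stronger inhibition and higher numbers for weaker inhibition), compound 1, `O=C(Nc1cccc(-c2nc(-c3ccc(NC(=O)c4cccnc4)cc3Cl)no2)c1)c1ccccc1`, gives 12800 nM, the highest of the two numbers in hand; the nearest is compound 2, `CC(=O)Nc1ccc(S(=O)(=O)Nc2cccc(-c3nc(-c4ccc(NC(=O)c5cccnc5)cc4Cl)no3)c2)cc1`, at 2500 nM, a gap beyond the scatter. Within the data shown here, compound 3, `CC(=O)Nc1ccc(S(=O)(=O)Nc2cccc(-c3nc(-c4ccc(NC(=O)c5cccnc5)cc4C(F)(F)F)no3)c2)cc1`, reaches only the limit > 10000 nM in this assay, and this is a limit, not a number; it is the one value sitting at the limit of > 10000 nM in this assay, at which 1 of the 3 values shown sits.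

Among the measured compounds shown here, the only single-point step measured is an at least 4.0-fold higher number from compound 2 to compound 3 (0.60 log units; beyond the scatter), which concerns the chloro group and does not touch the carbonyl end of the molecule. The change from compound 1 to compound 4, `CS(=O)(=O)Nc1cccc(NC(=O)Nc2cccc(-c3nc(-c4ccc(NC(=O)c5cccnc5)cc4Cl)no3)c2)c1`, is (3-(methanesulfonamido)phenyl)amino in place of phenyl on a carbonyl carbon. For the measured compounds named here, no measured pair isolates this change. What the numbers show is that compound 2, which also carries an anilide-type substituent at that end of the scaffold, sits well below compound 1 in this assay, while compound 3 shows that a change at the chloro position can erase that gain.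

Compound 4 is therefore expected to improve on compound 1, with the estimated step of a 3.7-fold lower number from compound 1 to compound 4 (0.56 log units; beyond the scatter). The estimate for compound 4 in this assay is 3500 nM, with a range from 1200 nM to 11000 nM.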

Compound 4, half-maximal inhibitory concentration: > 10000 nM
Compound 4 ended at the assay's limit (the forecaster's own chance of this, stated with the estimate: 12%); at least 2.8-fold (0.45 log units) between middle value and limit.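

In this assay compound 4 gives > 10000 nM, which is a limit and not a number: the limit of > 10000 nM in this assay, at which 2 of the 4 values shown sit.

The step from compound 1 to compound 4 therefore cannot be read. The compounds shown leave open what size of change, if any, (3-(methanesulfonamido)phenyl)amino in place of phenyl on a carbonyl carbon brings to the read-out.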